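Methoxy for hydrogen on a stilbene-type core

This account rests on a few compounds, and the source may have more. Where it says the series, first, only, none or still open, it means among the compounds named here.

Compound 1: `Fc1cccc(/C=C/c2ccccc2)c1` — 3100 nM
Compound 2: `Cc1ccc(/C=C/c2cccc(F)c2)cc1` — 800 nM
Compound 3: `COc1cccc(/C=C/c2ccccc2F)c1` — 3800 nM

In an assay on HepG2 cells for activation of nuclear factor erythroid 2-related factor 2 (Homo sapiens), read by a luciferase reporter, with a stated time of 5 h (on this read-out lower numbers stand for an effect already at smaller amounts and higher numbers for an effect only at larger amounts of compound), compound 1 gives 3100 nM, the second highest of the three numbers. Compound 3 gives 3800 nM, which lies within the scatter of compound 1, so the two are not told apart. Among the compounds with values here, compound 2 gives 800 nM, and the step of a 3.9-fold lower number from compound 1 to compound 2 (0.59 log units; beyond the scatter) is the only measured step and the only one that bears on the change considered here.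

The unmeasured compound 4, `COc1cccc(/C=C/c2cccc(F)c2)c1`, differs from compound 1 by methoxy in place of hydrogen on an aromatic carbon. Within the data shown here, the change is of the same kind as the one from compound 1 to compound 2, a small group entering on an aromatic carbon of the shared core, but the group is different, and no measured pair shows methoxy replacing hydrogen at this position. The step of a 3.9-fold lower number from compound 1 to compound 2 (0.59 log units; beyond the scatter) was modest yet beyond the scatter, so a lower number of comparable or smaller size is expected, with the possibility that it stays within the scatter. Compound 4 is therefore estimated at 1500 nM in this assay, between 500 nM and 4500 nM, meaning an expected step of a 2.1-fold lower number from compound 1 to compound 4 (0.32 log units; beyond the scatter).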

Compound 4, half-maximal effective concentration: 2300 nM
The estimate for compound 4 lay 1.5-fold (0.19 log units) below the measured number; the range from low to high includes it.
By their numbers in this assay, from the lowest: compound 2; then compounds 4, 1 and 3 (each within the scatter of the next).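

In this assay methoxy in place of hydrogen on an aromatic carbon, meta to a group of 9 heavy atoms, gives a 1.3-fold lower number from compound 1 to compound 4 (0.13 log units; within the scatter) and so cannot be told apart from the hydrogen of compound 1 at this place. Methyl in place of hydrogen had given a 3.9-fold lower number from compound 1 to compound 2 (0.59 log units; beyond the scatter) and stood as the only measured change, so compound 4 adds that a small group entering on an aromatic carbon of the shared core does not by itself bring a step beyond the scatter. Nothing at hand explains why the two steps differ.

The compounds shown leave open whether a hydroxyl, an amine or a carboxylic acid in this place would move the number beyond the scatter. They also leave open whether methoxy on another aromatic carbon of the shared core would do so.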